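This account rests on a few compounds, and the source may have more. Where it says the series, first, only, none or still open, it means among the compounds named here.

In an ADME assay on THP-1 cells (Homo sapiens) for cytotoxicity, read by MTT assay (a lower number here means that less compound is tolerated, a higher number that more compound is tolerated), compound 1 (`ClC(Cl)(Cl)c1nc(-c2ccccc2)c2ccccc2n1`) gives > 500000 nM, which is a limit. Compound 3 (`Clc1ccc(-c2nc(C(Cl)(Cl)Cl)nc3ccccc23)cc1`) gives > 500000 nM, again only a limit. Compound 2 (`Fc1ccc(-c2nc(C(Cl)(Cl)Cl)nc3ccccc23)cc1`) gives a true number, 500000 nM. Compound 3 therefore stands at the limit of > 500000 nM in this assay, at which 2 of the 3 values shown sit. Compound 4 (`ClC(Cl)(Cl)c1nc(-c2ccco2)c2ccccc2n1`) carries furan-2-yl in place of 4-chlorophenyl on an aromatic carbon. The measured steps exchange only hydrogen, fluoro and chloro on an aromatic carbon: a number no higher from compound 1 to compound 2 (the limit leaves the size open), a step that the two limits leave unreadable from compound 1 to compound 3 and a number no lower from compound 2 to compound 3 (the limit leaves the size open). None has a readable size, and none replaces the whole aromatic ring. The expected change, an at least 1.2-fold lower number from compound 3 to compound 4 (0.09 log units; that floor lies within the scatter), is estimated to stay within the scatter, downward if anything. Compound 4 is estimated at 400000 nM, with an expected range of 120000 nM to 800000 nM.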

Compound 4, concentration lethal to 50% of the cells: > 500000 nM
Compound 4: only a limit was reported; the forecaster's own chance of this, stated with the estimate: 50%; at least 1.2-fold (0.09 log units) between middle value and limit.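

Compound 4 is the first of these compounds in which the whole aromatic ring at this position is exchanged, not just a substituent on it, and a five-membered ring with an oxygen leaves the result in this assay at the same limit: the limit of > 500000 nM in this assay, at which 3 of the 4 values shown sit.

Among these compounds, the only step with a readable direction is a number no lower from compound 2 to compound 4 (the limit leaves the size open). The steps to compound 4 from compound 1 and compound 3 cannot be read, as both ends are limits.

On these data alone, how far these limits lie from the true values stays open. So does what an amine in place of the ring at this position would give.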